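Swapping ethynyloxy for hydroxy on the shared core

The source may hold more compounds than are shown below. What is called first, only, known or untested is meant among the compounds shown, and "the series" means these compounds.

In an ADME assay on L1210/0 cells (Mus musculus) for cytotoxicity, with a stated time of 48 h (a higher number here means a weaker inhibitor, a lower number a stronger inhibitor), compound 1 `O=c1[nH]c(=O)n([C@H]2C[C@H](O)[C@@H](CO)O2)cc1[N+](=O)[O-]` gives 130 nM, and compound 2 `C=Cc1cn([C@H]2C[C@H](O)[C@@H](CO)O2)c(=O)[nH]c1=O` gives 14200 nM. Compound 3 `C#COc1cn([C@H]2C[C@H](O)[C@@H](CO)O2)c(=O)[nH]c1=O` gives > 200000 nM, which is a limit of the assay and not a number. The evidence on this reading is short: the limit of > 200000 nM in this assay, at which 1 of the 3 values shown sits. The measured steps are an at least 1500-fold higher number from compound 1 to compound 3 (3.18 log units; beyond the scatter) and an at least 14-fold higher number from compound 2 to compound 3 (1.14 log units; beyond the scatter), so compound 3 is the weakest of the three.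

Compound 4 `O=c1[nH]c(=O)n([C@H]2C[C@H](O)[C@@H](CO)O2)cc1O` differs from it in one place: hydrogen in place of ethynyl on an oxygen on an aromatic ring. This is hydrogen in place of ethynyl on an oxygen on an aromatic ring, which turns ethynyloxy into hydroxy. Within the data shown here, no measured pair makes this exact change, so the estimate is uncertain. The closest guide is that each group swap at this place has so far moved the number a long way, including a 110-fold higher number from compound 1 to compound 2 (2.04 log units; beyond the scatter). Compound 3 also has its reading at a limit, so any measurable change can only be towards a lower number. A sizeable step in that direction is therefore expected in this assay, on the scale of an at least 14-fold higher number from compound 2 to compound 3 (1.14 log units; beyond the scatter). The estimated change is an at least 6.6-fold lower number from compound 3 to compound 4 (0.82 log units; beyond the scatter). For compound 4 the expected value is 30000 nM, with a likely range from 3000 nM to 200000 nM.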

Compound 4, half-maximal inhibitory concentration: > 200000 nM
Compound 4 gave a limit, no number; the forecaster's own chance of this, stated with the estimate: 25%; middle value at least 6.6-fold (0.82 log units) from the limit.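

In this assay compound 4 reads > 200000 nM, which is a limit of the assay and not a number, so the step between compound 3 and compound 4 cannot be read. What this adds is that taking the ethynyl off the oxygen does not bring back a measurable reading: hydroxy, like ethynyloxy, leaves this place on the shared core without a number. Among the four groups shown, the two that put an oxygen on this aromatic carbon both end at the limit, while nitro and vinyl both give numbers, and hydroxy stands far from each of them: an at least 14-fold higher number from compound 2 to compound 4 (1.14 log units; beyond the scatter) and an at least 1500-fold higher number from compound 1 to compound 4 (3.18 log units; beyond the scatter).

Where compound 3 and compound 4 truly stand relative to each other stays open, as the assay gives no number for either: the limit of > 200000 nM in this assay, at which 2 of the 4 values shown sit. It also remains open whether any group joined through oxygen ends at this limit, or whether a methoxy group or an amine at this place would give a measurable number.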